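The compounds below may be only part of what the source reports. "The series", "measured", "known", "first", "only" and "open" are said of these compounds alone.

Going by the values given here, compound 3 `C/C(=C\C(=O)Nc1ccccc1OCCCC(=O)O)c1ccc2c(ccn2Cc2ccccc2C)c1` carries a 2-methylphenyl on a saturated chain carbon bound to an aromatic nitrogen; in an assay on Prostate gland for inhibition of steroid 5-alpha-reductase (Rattus norvegicus) (on this read-out lower numbers stand for stronger inhibition and higher numbers for weaker inhibition), compound 3 gives 69 nM, the lowest of the three numbers so far. Its neighbours differ only at that carbon. Compound 1 `C/C(=C\C(=O)Nc1ccccc1OCCCC(=O)O)c1ccc2c(ccn2CC(C)C)c1`, with isopropyl there, gives 160 nM in this assay, and compound 2 `CC(C)=CCn1ccc2cc(/C(C)=C/C(=O)Nc3ccccc3OCCCC(=O)O)ccc21`, with 2-methylprop-1-en-1-yl, gives 120 nM. The steps are a 2.3-fold lower number from compound 1 to compound 3 (0.37 log units; beyond the scatter) and a 1.7-fold lower number from compound 2 to compound 3 (0.24 log units; within the scatter); the pair of compound 1 and compound 2 shows a 1.3-fold lower number from compound 1 to compound 2 (0.12 log units; within the scatter). All variation at this carbon has so far stayed small.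

Compound 4 `C/C(=C\C(=O)Nc1ccccc1OCCCC(=O)O)c1ccc2c(ccn2Cc2ccc(C(F)(F)F)cc2)c1` is the next change at the same place: 4-(trifluoromethyl)phenyl in place of 2-methylphenyl on a saturated chain carbon bound to an aromatic nitrogen. Among the compounds with values here, the steps that bear on it are those just given, of which only the one from compound 1 to compound 3 crossed the scatter, and modestly. Within the data shown here, no measured step exchanges one aryl for another at this carbon, so the direction is open. The expectation is a step of a 1.2-fold higher number from compound 3 to compound 4 (0.09 log units; within the scatter) in this assay, not clearly beyond the scatter. Compound 4 is therefore estimated at 85 nM in this assay, with a range from 30 nM to 240 nM.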

Compound 4, half-maximal inhibitory concentration: 300 nM
Beside the measured number, compound 4's estimate is 3.5-fold (0.55 log units) below it; the whole stated range lies below it.
By their numbers in this assay, from the lowest: compounds 3, 2, 1 and 4 (each within the scatter of the next, the first and the last beyond it).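

In this assay, going by these compounds alone, this carbon is not as flat as the earlier compounds suggested: exchanging one aryl group for another gives a 4.3-fold higher number from compound 3 to compound 4 (0.64 log units; beyond the scatter) and is the largest step seen here so far. An aryl group on this carbon therefore does not by itself go with the lowest number, since 4-(trifluoromethyl)phenyl gives a 2.5-fold higher number from compound 2 to compound 4 (0.40 log units; beyond the scatter) against the 2-methylprop-1-en-1-yl group, whereas against isopropyl the reading is a 1.9-fold higher number from compound 1 to compound 4 (0.27 log units; within the scatter) and stays inside the usual spread of repeats. No measurement offered alongside these numbers accounts for the difference between the two aryl groups.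

The groups in compound 3 and compound 4 differ both in the substituent and in where it sits on the phenyl ring, so the compounds shown cannot separate these two changes; 4-methylphenyl and 2-(trifluoromethyl)phenyl at this carbon would do so. Unsubstituted phenyl would give the reference that neither aryl compound provides, and it remains open whether a ring bearing an amine or a carboxylic acid would follow either of them.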